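Working notes: from (oxetan-2-yl)methyl to isobutyl on the shared core

A few compounds are considered here, and "the series" means these few. Any claim that something is new, unique, unknown or untested is made for them only; others in the source may bear on it.

The series is followed in a functional assay on FaDu cells (Homo sapiens) for cytotoxicity, read by MTT assay, with a stated time of 72 h; on this read-out higher numbers stand for lower toxicity in this test and lower numbers for higher toxicity in this test. Compound 1 `COC(=O)CCn1cc(C(=O)C(=O)Nc2ccc(OC)nc2)c2ccccc21` gives 168 nM, and compound 3 `COc1ccc(NC(=O)C(=O)c2cn(CC3CCO3)c3ccccc23)cn1` gives 686 nM. Compound 2 `COCCn1cc(C(=O)C(=O)Nc2ccncc2)c2ccccc21` returns a limit and not a number: > 10000 nM. Among the compounds with values here, compound 2 differs from the other two in more than one place, so it offers no clean step. Of the two true numbers, compound 3 holds the higher, and compound 1 lies below it beyond the scatter.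

The next structure is compound 4 `COc1ccc(NC(=O)C(=O)c2cn(CC(C)C)c3ccccc23)cn1`, with isopropyl in place of oxetan-2-yl on a saturated chain carbon bound to an aromatic nitrogen. The same difference, cut one bond further out, reads (oxetan-2-yl)methyl to isobutyl.

Within the data shown here, only one measured step touches this place: a 4.1-fold higher number from compound 1 to compound 3 (0.61 log units; beyond the scatter). It is modest, and it involves a different outgoing group, so it serves as a guide to size and sets no firm direction. A change of similar size either way remains possible, but no shift beyond the scatter is expected. The expected step is a 1.4-fold lower number from compound 3 to compound 4 (0.14 log units; within the scatter). For compound 4 the estimated value is 500 nM, with an expected range of 150 nM to 2000 nM.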

Compound 4, concentration lethal to 50% of the cells: 317 nM
Compound 4: middle estimate off by 1.6-fold (0.20 log units), on the high side; low and high end bracket the measured number.
By their numbers in this assay, from the lowest: compounds 1 and 4 (each within the scatter of the next); then compound 3. At a limit, above all of these: compound 2.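

In this assay, isopropyl in place of oxetan-2-yl on a saturated chain carbon bound to an aromatic nitrogen gives a 2.2-fold lower number from compound 3 to compound 4 (0.34 log units; beyond the scatter), so a group with no ring and no hydrogen-bond acceptor reads on the side of higher toxicity in this test. Isopropyl in place of (methoxycarbonyl)methyl at the same place gives a 1.9-fold higher number from compound 1 to compound 4 (0.28 log units; within the scatter), which leaves oxetan-2-yl as the one group of these three that stands apart on this read-out. Nothing measured here gives a cause for either step.

The compounds shown leave open whether the step from compound 3 belongs to the four-membered ring or to its oxygen, and a cyclobutyl group at this place would separate the two. Also open, from the compounds shown here alone, is how an amine or a carboxylic acid on this chain would read, and whether the oxetan-2-yl to isopropyl step holds with a different amide partner on the shared core.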